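The source may report more compounds than this note shows. Statements on the series, on what has been measured and on what is new or still open speak of the compounds shown alone.

In an ADME assay on Caco-2 cells (Homo sapiens) for permeability, read by LC-MS, in the apical to basolateral direction, with a stated time of 60 min, at pH 6.5 (on this read-out lower numbers stand for lower permeability and higher numbers for higher permeability), compound 2 `O=C(NCc1cc(Cl)ccc1-n1cnnn1)[C@@H]1C[C@@H]2C[C@@H]2N1C(=O)[C@H](O)C1CCCCC1` gives 16 10^-6 cm/s, the highest of the three measured numbers and beyond the scatter of both others, compound 1 `O=C(NCc1cc(Cl)ccc1-n1cnnn1)[C@@H]1CC=NN1C(=O)[C@H](O)c1ccccc1` at 7 10^-6 cm/s and compound 3 `O=C(NCc1cc(Cl)ccc1-n1cnnn1)[C@@H]1[C@@H]2C[C@@H]2CN1C(=O)[C@H](O)c1ccccc1F` at 2.3 10^-6 cm/s. Compound 4 `COC(C)(C)[C@@H](O)C(=O)N1[C@H](C(=O)NCc2cc(Cl)ccc2-n2cnnn2)C[C@@H]2C[C@@H]21` has not yet been measured. It differs from compound 2 by 1-methoxy-1-methylethyl in place of cyclohexyl on a saturated chain carbon bound to a carbonyl carbon and an oxygen on a saturated carbon, with 1-methoxy-1-methylethyl in place of cyclohexyl on a saturated chain carbon bound to a carbonyl carbon and an oxygen on a saturated carbon. Within the data shown here, no measured pair shows this change, so the expectation is tentative. Compound 2, at 16 10^-6 cm/s, already tops this small set, so a fall seems likelier than a rise. The expected change, a 2.7-fold lower number from compound 2 to compound 4 (0.43 log units; beyond the scatter), is a drop modestly beyond the scatter. Compound 4 is estimated at 6 10^-6 cm/s, with an expected range from 2.5 10^-6 cm/s to 14 10^-6 cm/s.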

Compound 4, apparent permeability: 16 10^-6 cm/s
Estimate against measurement, compound 4: 2.7-fold (0.43 log units) below; measured number above the stated range.
By their numbers in this assay, from the lowest: compound 3; then compound 1; then compounds 2 and 4 (each within the scatter of the next).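

In this assay, replacing cyclohexyl with 1-methoxy-1-methylethyl on this saturated chain carbon gives no change at the digits printed from compound 2 to compound 4 (within the scatter). So, in this one pair, the carbon-only ring can give way to an open group carrying a hydrogen-bond acceptor with no visible shift in the read-out. The data shown offer no measurement that explains this result. As far as these compounds go, this is a single pair, so it remains open whether the same swap would behave alike on the core of compound 1 or compound 3. From the compounds shown here alone, what an amine or a carboxylic acid at this place would give also remains open.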